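The source may report more compounds than this note shows. Statements on the series, on what has been measured and on what is new or still open speak of the compounds shown alone.

Measured in a functional assay on RAW264.7 cells (Mus musculus) for inhibition, read by fluorescence, with stated times of 1 h, 24 h and 30 min; a higher number here means a weaker inhibitor, a lower number a stronger inhibitor:
Compound 1 `O=C(/C=C/c1ccccc1F)c1cccc(O)c1`: > 10000 nM
Compound 2 `O=C(/C=C/c1cccc(F)c1)c1ccccc1O`: > 10000 nM
Compound 3 `O=C(/C=C/c1ccc(F)cc1)c1ccc(O)cc1`: > 10000 nM

Each of these readings is a limit of the assay and not a number. Compound 3 stands at > 10000 nM, which is likewise only a limit. Within the data shown here, the whole series so far comes down to one line: the limit of > 10000 nM in this assay, at which 3 of the 3 values shown sit.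

Compound 4 `O=C(/C=C/c1ccc(C(F)(F)F)cc1)c1ccc(O)cc1` has trifluoromethyl in place of fluoro on an aromatic carbon, para to a large group: trifluoromethyl in place of fluoro on an aromatic carbon. Among the measured compounds shown here, no measured step in this assay covers such a change. Only a small change, with no direction expected beyond the scatter, is estimated as a step that the limit leaves unreadable from compound 3 to compound 4. For compound 4 the expected value is 12000 nM, with an estimated range from 4000 nM to 30000 nM.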

Compound 4, half-maximal inhibitory concentration: > 10000 nM
Compound 4: a limit, no number (the forecaster's own chance of this, stated with the estimate: 70%); the middle value is on the limit's open side.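

Compound 4, like compound 3, gives only a limit and no number, so no step between them can be read: the limit of > 10000 nM in this assay, at which 4 of the 4 values shown sit.

The compounds shown leave open how strongly any of them inhibits in this assay, and which change to the shared core would bring a reading inside the limit.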